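Cyclopentyl for Benzyl on the Shared Core

This account rests on a few compounds, and the source may have more. Where it says the series, first, only, none or still open, it means among the compounds named here.

Of the compounds shown here, two have been measured in a functional assay on HCT-116 cells (Homo sapiens) for antiproliferative activity, read by CCK-8 assay, with a stated time of 72 h, tested at 8 uM; on this read-out lower numbers stand for a weaker effect and higher numbers for a stronger effect at the one concentration tested. Compound 1 `Nc1ccccc1NC(=O)c1ccc(Cn2cnc3c(Nc4cccc(OC(F)(F)F)c4)nc(Cl)nc32)cc1` gives 46.6%. Compound 2 `Nc1ccccc1NC(=O)c1ccc(CNc2nc(Cl)nc3c2ncn3Cc2ccccc2)cc1` gives 11.5%, the lowest of the two numbers, with compound 1 standing higher by a gap beyond the scatter. Compound 3 `Nc1ccccc1NC(=O)c1ccc(CNc2nc(Cl)nc3c2ncn3C2CCCC2)cc1` differs from compound 2 by cyclopentyl in place of benzyl on an aromatic nitrogen. Going by the values given here, no measured step of this kind exists, so the expectation rests on compound 2 alone. Compound 3 is expected to sit close to that level, so the step of a number 3.5 percentage points higher from compound 2 to compound 3 (within the scatter) is expected to lie within the scatter. Compound 3 is therefore estimated at 15%, between 2% and 35%.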

Compound 3, a percentage reported as inhibition, at one concentration (the size of the read-out at that concentration, not a potency): 80.6%
Beside the measured number, compound 3's estimate is 65.6 percentage points below it, and the stated range ends below it.
By their numbers in this assay, from the lowest: compound 2; then compound 1; then compound 3.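

In this assay, cyclopentyl in place of benzyl on the aromatic nitrogen brings a number 69.1 percentage points higher from compound 2 to compound 3 (beyond the scatter) and shows that this position is far from indifferent to the group it carries. The two groups hold no hydrogen-bond donors or acceptors, so the large step comes with no change in those counts. Nothing available here accounts for the size of this step.

Going by these compounds, it remains open whether cyclohexyl, isopropyl or a longer alkyl chain on this nitrogen would match cyclopentyl. Whether the same exchange would give a similar step on the core of compound 1 is also unresolved.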